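Amine tail variation in an antiproliferative series

The source may report more compounds than this note shows. Statements on the series, on what has been measured and on what is new or still open speak of the compounds shown alone.

Measured so far in a functional assay on BCG823 cells (Homo sapiens) for antiproliferative activity, read by MTT assay, with a stated time of 48 h; a higher number here means a weaker inhibitor, a lower number a stronger inhibitor:

Compound 1, `CCN(CC)CCCCOc1c(OCc2ccccc2)cc2oc(-c3ccccc3)cc(=O)c2c1O`, gives 4200 nM.
Compound 2, `O=c1cc(-c2ccccc2)oc2cc(O)c(OCCCN3CCCC3)c(O)c12`, gives only a limit of the assay, > 100000 nM.
Compound 3, `COc1cc2oc(-c3ccccc3)cc(=O)c2c(O)c1OCCCN1CCN(C)CC1`, gives 31300 nM.

Compound 1 holds the lowest of the two numbers recorded; compound 3 sits at a markedly higher number, beyond the usual scatter. The limit for compound 2 is one of the values that sit at the assay ceiling (the limit of > 100000 nM in this assay, at which 1 of the 3 values shown sits). No pair among these three differs in a single place, so no measured step is available.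

The next compound, compound 4, `CN1CCN(CCCCOc2c(OCc3ccccc3)cc3oc(-c4ccccc4)cc(=O)c3c2O)CC1`, differs from compound 1 in one place: 4-methylpiperazin-1-yl in place of diethylamino on a saturated chain carbon, four bonds along the chain from an oxygen on an aromatic ring. Compound 3 also carries a 4-methylpiperazin-1-yl tail and gives 31300 nM, but it differs from compound 1 in more than one place, so it only hints at direction. In this assay compound 4 is expected to be somewhat weaker, a step from compound 1 of a 2.4-fold higher number from compound 1 to compound 4 (0.38 log units; beyond the scatter), beyond the scatter but modest. The estimate for compound 4 in this assay is 10000 nM, with a range from 3000 nM to 40000 nM.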

Compound 4, half-maximal inhibitory concentration: 7200 nM
Compound 4: middle estimate off by 1.4-fold (0.14 log units), on the high side; low and high end bracket the measured number.
By their numbers in this assay, from the lowest: compounds 1 and 4 (each within the scatter of the next); then compound 3. At a limit, above all of these: compound 2.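

For the compounds shown here, at this place, on a saturated chain carbon, four bonds along the chain from an oxygen on an aromatic ring, the series now has its first single-place exchange: in this assay, 4-methylpiperazin-1-yl in place of diethylamino gives a 1.7-fold higher number from compound 1 to compound 4 (0.23 log units; within the scatter), the only measured step so far. On this read-out, with the rest of compound 1 held fixed, the open-chain amine and the ring-bearing tail are not told apart. Nothing measured here bears on why the two tails read alike.

On these data alone, whether a morpholine or piperidine tail on the same chain would also read alike remains open. Compound 3 and compound 4 share the 4-methylpiperazin-1-yl tail but differ in more than one place, so the contribution of chain length and of the other ring substituents cannot be separated.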